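The source may report more compounds than this note shows. Statements on the series, on what has been measured and on what is new or still open speak of the compounds shown alone.

Compound 3 `Fc1ccc(Nc2nc3nonc3nc2Nc2ccccc2F)cc1` stands lowest of the two numbers reported in an assay on mitochondria from L6 cells (Rattus norvegicus) for activation, with a stated time of 90 min; a higher number here means that more compound is needed for the effect, a lower number that less compound is needed; the nearest is compound 2 `CCOc1cccc(Nc2nc3nonc3nc2Nc2cccc(OCC)c2)c1`, which in this assay gives 10100 nM, a gap beyond the usual scatter. Compound 3 itself gives 2300 nM in this assay. Compound 1 `COc1cccc(Nc2nc3nonc3nc2Nc2cccc(OC)c2)c1` returns only a limit of the assay, > 100000 nM, so for it no number is known; that is the limit described by the limit of > 100000 nM in this assay, at which 1 of the 3 values shown sits.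

Compound 4 `COc1cccc(Nc2nc3nonc3nc2Nc2ccccc2F)c1` is not yet measured in this assay. It differs from compound 3 in one place: 3-methoxyphenyl in place of 4-fluorophenyl on a nitrogen on an aromatic ring. Among the compounds with values here, no step between measured compounds shows this exact change. What the data do show is that compound 1, which carries the 3-methoxyphenyl group on both nitrogens, sits at the limit of this assay, while compound 3, with fluorophenyl groups on both, gives the lowest number. On that basis compound 4 is expected to need more compound than compound 3, a step of a 3.5-fold higher number from compound 3 to compound 4 (0.54 log units; beyond the scatter) beyond the scatter. Compound 4 is estimated at 8000 nM, within a range from 2500 nM to 30000 nM.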

Compound 4, half-maximal effective concentration: 830 nM
Estimate against measurement, compound 4: 9.6-fold (0.98 log units) above; the whole stated range lies above it.
By their numbers in this assay, from the lowest: compound 4; then compound 3; then compound 2. At a limit, above all of these: compound 1.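

In this assay, the 3-methoxyphenyl group on a nitrogen on an aromatic ring does not by itself bring a high number: set against 4-fluorophenyl at this place, with 2-fluorophenyl on the other nitrogen, it gives a 2.8-fold lower number from compound 3 to compound 4 (0.44 log units; beyond the scatter). The group on the other nitrogen counts as well, since 2-fluorophenyl in place of one of the two 3-methoxyphenyl groups gives an at least 120-fold lower number from compound 1 to compound 4 (2.08 log units; beyond the scatter). For compound 1 the assay gives only a limit and not a number: the limit of > 100000 nM in this assay, at which 1 of the 4 values shown sits.

As far as these compounds go, whether 3-methoxyphenyl keeps its advantage over 4-fluorophenyl with any partner other than 2-fluorophenyl remains open. From the compounds shown here alone, it is equally open how an amine, a carboxylic acid or a longer alkoxy chain on the phenyl ring at this place would compare with the methoxy group.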